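A few compounds are considered here, and "the series" means these few. Any claim that something is new, unique, unknown or untested is made for them only; others in the source may bear on it.

Compound 3 `Cc1ccc(-c2noc(CCCCCCC(=O)Nc3ccccc3N)n2)cc1`, an amide carrying a 2-aminophenyl group, was measured in an assay on isolated protein for inhibition of histone deacetylase 8 (Homo sapiens), read by fluorescence, with a stated time of 10 min (a higher number here means a weaker inhibitor, a lower number a stronger inhibitor), and gave 8390 nM. Among the three compounds with numbers, that is the highest. Compound 1 `Cc1ccc(-c2noc(CCCCCCC(=O)NO)n2)cc1`, which carries a hydroxy group on the same amide nitrogen, gave 5390 nM in this assay; the step of a 1.6-fold higher number from compound 1 to compound 3 (0.19 log units; within the scatter) is within the scatter. Compound 2 `O=C(CCCCCCc1nc(-c2cccc([N+](=O)[O-])c2)no1)NO`, built on a related core with a nitro group on its phenyl ring, gave 2380 nM in this assay, the lowest of the three and beyond the scatter from compound 3.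

Compound 4 `Nc1ccccc1NC(=O)CCCCCCc1nc(-c2ccccc2Cl)no1` differs from compound 3 at the aryl group on the shared core: 2-chlorophenyl in place of 4-methylphenyl on an aromatic carbon. Within the data shown here, none of the measured steps changes that aryl group alone; the single-change step known here alters the amide end instead. Compounds 1 and 2 differ in more than one place, so their two values give no clean reading on the aryl ring. Among the measured compounds shown here, with no step bearing on this change, the expected step of a 1.2-fold lower number from compound 3 to compound 4 (0.08 log units; within the scatter) is none beyond the scatter. Compound 4 is therefore estimated at 7000 nM in this assay, within a range from 2500 nM to 20000 nM.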

Compound 4, half-maximal inhibitory concentration: > 10000 nM
Compound 4 gave a limit, no number (the forecaster's own chance of this, stated with the estimate: 10%); middle value at least 1.4-fold (0.15 log units) from the limit.
By their numbers in this assay, from the lowest: compound 2; then compounds 1 and 3 (each within the scatter of the next). At a limit, above all of these: compound 4.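

In this assay compound 4 reaches a limit and not a number: the limit of > 10000 nM in this assay, at which 1 of the 4 values shown sits. Among these compounds, this gives the first reading on the aryl group alone, as 2-chlorophenyl in place of 4-methylphenyl on the shared core gives an at least 1.1-fold higher number from compound 3 to compound 4 (0.07 log units; that floor lies within the scatter). The floor of that step lies within the scatter, so the change is not shown to weaken inhibition, and how far compound 4 really sits from compound 3 remains unknown.

Going by these compounds, the 2-chlorophenyl group appears here only with the 2-aminophenyl amide, so it remains open whether the same change would read alike with the hydroxy group of compound 1 on that amide nitrogen. Also open, on these data alone, is how the series would respond to a fluorine atom or a methoxy group on the phenyl ring in place of the chlorine.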